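From 1,3-thiazol-2-yl to pyridin-4-yl on a shared core

The compounds below may be only part of what the source reports. "The series", "measured", "known", "first", "only" and "open" are said of these compounds alone.

Measured in a physicochemical assay for solubility, in phosphate buffer, with a stated time of 18 h; a higher number here means a more soluble compound, a lower number a less soluble compound:
Compound 1 `N#Cc1c(N)nc2nc(Cc3ccccc3)ncc2c1N`: 13000 nM
Compound 2 `Cc1nc(C(C)(C)C)nc2nc(N)c(C#N)c(N)c12`: 37000 nM
Compound 3 `CC(C)(C)c1nc(-c2nccs2)c2c(N)c(C#N)c(N)nc2n1`: < 1500 nM (a limit of the assay, not a number)

Compound 3 has no exact number in this assay, only a limit: the limit of < 1500 nM in this assay, at which 1 of the 3 values shown sits.

Compound 4 `CC(C)(C)c1nc(-c2ccncc2)c2c(N)c(C#N)c(N)nc2n1` has not been measured yet. It differs from compound 3 in one group on an aromatic carbon, with pyridin-4-yl in place of 1,3-thiazol-2-yl on an aromatic carbon.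

For the measured compounds named here, only one measured step bears on this change: an at least 24-fold lower number from compound 2 to compound 3 (1.39 log units; beyond the scatter). That large step put 1,3-thiazol-2-yl in place of methyl, so a methyl gave way to an aromatic ring. The new change instead replaces one aromatic ring with another, which makes the earlier step only a loose guide. Compound 4 keeps an aromatic ring in that place, so the drop seen in an at least 24-fold lower number from compound 2 to compound 3 (1.39 log units; beyond the scatter) is not expected to be undone. No step beyond the scatter is expected, with a slight lean towards a higher number. The estimated step is an at least 1.2-fold higher number from compound 3 to compound 4 (0.07 log units; that floor lies within the scatter). The estimate for compound 4 is 1800 nM, with an expected range from 700 nM to 8000 nM.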

Compound 4, solubility: 44000 nM
Compound 4: middle estimate off by 24-fold (1.39 log units), on the low side; the whole stated range lies below it.
By their numbers in this assay, from the lowest: compound 1; then compounds 2 and 4 (each within the scatter of the next). At a limit, below all of these: compound 3.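

In this assay, pyridin-4-yl in place of methyl gives a 1.2-fold higher number from compound 2 to compound 4 (0.08 log units; within the scatter), whereas 1,3-thiazol-2-yl in place of methyl gave an at least 24-fold lower number from compound 2 to compound 3 (1.39 log units; beyond the scatter). Among these compounds, then, an aromatic ring on this carbon does not by itself go with a low number, and the identity of the ring makes a large difference, seen in an at least 29-fold higher number from compound 3 to compound 4 (1.46 log units; beyond the scatter). Compound 3 has a limit and not a number, so the true size of that step stays unknown and the printed figure is only a floor: the limit of < 1500 nM in this assay, at which 1 of the 4 values shown sits.

The two rings differ at once in ring size and in hetero atoms, with sulfur in only one of them, and the compounds shown cannot separate these differences. From the compounds shown here alone, whether a plain phenyl ring, which has no ring nitrogen, or a pyridin-2-yl ring, whose nitrogen lies elsewhere in the ring, would give a number close to that of compound 4 or fall to the level of compound 3 remains open.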